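Phenyl for bromo on a fused aromatic carbon

This account rests on a few compounds, and the source may have more. Where it says the series, first, only, none or still open, it means among the compounds named here.

Compound 1 `Cc1c(C(=O)Nc2ccc(Oc3ncnc4[nH]cc(-c5ccccc5)c34)c(F)c2)c(=O)c2cc(Br)ccc2n1C` gives 3120 nM in an assay on isolated protein for inhibition of tyrosine-protein kinase receptor UFO (Homo sapiens), read by FRET and Z'-LYTE, with a stated time of 1.5 h; on this read-out higher numbers stand for weaker inhibition and lower numbers for stronger inhibition.
Compound 2 `CCc1ccc2c(c1)c(=O)c(C(=O)Nc1ccc(Oc3ccnc(N)c3Cl)c(F)c1)c(C)n2C` gives 72 nM in this assay.

Among the two numbers measured, compound 1 stands highest in this assay. Compound 2 differs from compound 1 in several places at once, so the two values show only a gap between them, not a step that can be traced to one change.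

Compound 3 `Cc1c(C(=O)Nc2ccc(Oc3ncnc4[nH]cc(-c5ccccc5)c34)c(F)c2)c(=O)c2cc(-c3ccccc3)ccc2n1C` has not been measured. It differs from compound 1 in a single place: phenyl in place of bromo on an aromatic carbon. Going by the values given here, no measured pair isolates a change of this kind, so the size and direction of the step are open. A modest step in either direction, or none beyond the scatter, seems plausible in this assay.

The expected step of a 1.2-fold lower number from compound 1 to compound 3 (0.10 log units; within the scatter) is therefore small. Compound 3 is expected to give about 2500 nM in this assay, within a range from 600 nM to 10000 nM.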

Compound 3, half-maximal inhibitory concentration: > 10000 nM
Compound 3 gave a limit, no number; the forecaster's own chance of this, stated with the estimate: 5%; middle value at least 4.0-fold (0.60 log units) from the limit.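

In this assay, going by these compounds alone, phenyl in place of bromo on an aromatic carbon of the shared core gives an at least 3.2-fold higher number from compound 1 to compound 3 (0.50 log units; beyond the scatter), the first traced step at this position, and it shows that this change does not leave inhibition intact on this core. Compound 3 gave only a limit, > 10000 nM, and not a number. The step therefore fixes a direction and a lowest size, while its full size stays unknown: the limit of > 10000 nM in this assay, at which 1 of the 3 values shown sits.

As far as these compounds go, whether an amine, a methoxy group or a nitrile on this carbon would hold the value of compound 1 remains open. Also open, from the compounds shown here alone, is whether phenyl would bring a similar loss on the core of compound 2, which differs from compound 1 in several places.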